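Phenyl for propyl on the amine of a coumarin amide

This account rests on a few compounds, and the source may have more. Where it says the series, first, only, none or still open, it means among the compounds named here.

Compound 2 `CCCNCCCOc1ccc2cc(NC(=O)c3ccc(O)c(CC=C(C)C)c3)c(=O)oc2c1C` gives 980 nM in a functional assay on MCF7 cells (Homo sapiens) for antiproliferative activity; a lower number here means a stronger inhibitor, a higher number a weaker inhibitor. Compound 1 `CC(=O)Oc1ccc(C(=O)Nc2cc3ccc(OCC4CCCN(C)C4)c(C)c3oc2=O)cc1CC=C(C)C` gives 1650 nM in this assay, and the two values lie within the usual scatter of each other, so neither stands apart. Compound 3 `CC(C)=CCc1cc(C(=O)Nc2cc3ccc(OCCCNc4ccccc4)c(C)c3oc2=O)ccc1O` differs from compound 2 by phenyl in place of propyl on an amine nitrogen. Going by the values given here, no measured pair shows this change, so the expectation rests on compound 2 alone, and the step from a 1.0-fold higher number from compound 2 to compound 3 (0.01 log units; within the scatter) is expected to stay within the scatter, in no clear direction. Compound 3 is therefore estimated at 1000 nM, with a range from 400 nM to 2500 nM in this assay.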

Compound 3, half-maximal inhibitory concentration: > 50000 nM
Compound 3 gave a limit, no number (the forecaster's own chance of this, stated with the estimate: 3%); at least 50-fold (1.69 log units) between middle value and limit.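

Replacing propyl with phenyl on the amine nitrogen gives an at least 51-fold higher number from compound 2 to compound 3 (1.70 log units; beyond the scatter), so activity in this assay depends strongly on the group at this place, which compound 2 alone could not show. For compound 3 the result is a limit, not a number: the limit of > 50000 nM in this assay, at which 1 of the 3 values shown sits.

The compounds shown leave open how far activity falls, and whether the loss follows the aromatic ring itself or simply the larger group. A cyclohexyl or benzyl group on the same nitrogen would separate these two readings.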